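The compounds below may be only part of what the source reports. "The series", "measured", "known", "first", "only" and "open" are said of these compounds alone.

Three compounds of this series carry a measured number in a physicochemical assay for acid dissociation: compound 1 `CC(=O)Nc1ccc(OC(=S)Nc2ccc(Nc3ccc(C(F)(F)F)cc3)cc2)cc1`, compound 2 `O=[N+]([O-])c1ccc(Sc2ccc(NC(=S)Oc3ccc(O)cc3)cc2)cc1` and compound 3 `O=[N+]([O-])c1ccc(Oc2ccc(NC(=S)Oc3ccc(O)cc3)cc2)cc1`. In this assay compound 1 gives 9.05. Compound 2 gives 9.21, and compound 3 gives 9.23. The gap from compound 2 to compound 3, and the gap from compound 2 to compound 1, both fall within the scatter of repeated runs, so the three numbers cannot be told apart. Compound 4 `Oc1ccc(OC(=S)Nc2ccc(Sc3ccc(C(Cl)(Cl)Cl)cc3)cc2)cc1` is not yet measured. It differs from compound 2 by trichloromethyl in place of nitro on an aromatic carbon, para to a large group. Among the measured compounds shown here, no measured pair shows this change. The step of a number 0.04 log units higher from compound 2 to compound 4 (within the scatter) is expected to be none beyond the scatter, given that compound 2 gives 9.21. Compound 4 is estimated at 9.25, with a range from 8.9 to 9.6.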

Compound 4, acid dissociation constant: 9.22
Compound 4: middle estimate off by 0.03 log units, on the high side; the range from low to high includes it.
By their numbers in this assay, from the lowest: compounds 1, 2, 4 and 3 (each within the scatter of the next).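

Among the compounds shown here, the first matched pair at this position shows that, in this assay, trichloromethyl in place of nitro on an aromatic carbon, para to a large group, gives a number 0.01 log units higher from compound 2 to compound 4 (within the scatter) and so leaves the read-out unresolved from its starting point. Earlier compounds offered no direct test of this change. No available evidence bears on this result.

On these data alone, whether an amine or a carboxylic acid on this carbon would also stay within the scatter of compound 2 remains open. So does whether the same change gives the same outcome on the core of compound 3.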